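Aryl swap on the amine nitrogen: compound 3 outlook

The compounds below may be only part of what the source reports. "The series", "measured", "known", "first", "only" and "open" are said of these compounds alone.

Measured so far:
compound 1 `COc1ccc(N(C)/C(S)=C2/C(=O)c3cc(Cl)ccc3N(C)C2=O)cc1` — 45%
compound 2 `CN1C(=O)/C(=C(/S)N(C)c2cccc(Cl)c2)C(=O)c2cc(Cl)ccc21` — 63%

Going by the values given here, in a functional assay on the whole organism for inhibition, with Mus musculus as the target, at a dose of 10 mg/kg by the oral route (on this read-out higher numbers stand for more inhibition at the one dose given (going by the name of the read-out) and lower numbers for less inhibition), compound 2 stands highest of the two numbers; its only neighbour is compound 1, and the step of a number 18 percentage points higher from compound 1 to compound 2 (beyond the scatter) lies beyond the scatter. Compound 3 `Cc1ccc(N(C)/C(S)=C2/C(=O)c3cc(Cl)ccc3N(C)C2=O)cc1` differs from compound 2 by 4-methylphenyl in place of 3-chlorophenyl on an amine nitrogen. Among the compounds with values here, the one step that bears on this change is a number 18 percentage points higher from compound 1 to compound 2 (beyond the scatter), where a different aryl group on the same nitrogen moved the read-out. Compound 3 is therefore expected to sit between the two measured values, with a step of a number 13 percentage points lower from compound 2 to compound 3 (beyond the scatter) expected. The estimate for compound 3 is 50%, range 30% to 70%.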

Compound 3, a percentage reported as inhibition, in the whole organism at one dose (the size of the read-out at that dose, not a potency): 23%
The estimate for compound 3 lay 27 percentage points above the measured number, and the stated range ends above it.
By their numbers in this assay, from the lowest: compound 3; then compound 1; then compound 2.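

In this assay this position proves more sensitive than the first step showed: the read-out falls with a number 40 percentage points lower from compound 2 to compound 3 (beyond the scatter) on exchanging 3-chlorophenyl for 4-methylphenyl, two groups with the same heavy-atom count. Methyl in place of methoxy on an aromatic carbon also matters, giving a number 22 percentage points lower from compound 1 to compound 3 (beyond the scatter) as the result. No measurement on hand explains either step. Open, going by these compounds, is whether the loss follows the identity of the group or its ring location, and how a carboxylic acid or an amine on this aryl group would read.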